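A few compounds are considered here, and "the series" means these few. Any claim that something is new, unique, unknown or untested is made for them only; others in the source may bear on it.

In an ADME assay on the whole organism (Macaca fascicularis) for metabolic stability (on this read-out higher numbers stand for a longer-lived compound and lower numbers for a shorter-lived compound), two compounds of the shared core have been measured. Compound 1 `Cc1ccc(-c2nc(=O)o[nH]2)c(-c2ccc([C@@H](C)N(CC3CC3)c3nc(C(=O)NS(=O)(=O)C4CC4)c(CC(C)C)s3)cc2)c1` gives 2.3 h in this assay. Compound 2 `Cc1ccc(-c2nc(=O)o[nH]2)c(-c2ccc([C@@H](C)N(CC3CC3)c3nc(C(=O)NS(=O)(=O)C4CC4)c(C4CCC4)s3)cc2)c1` carries a cyclobutyl in place of the isobutyl of compound 1 on an aromatic carbon. In this assay compound 2 gives 2.8 h. Among the compounds with values here, the only step so far, a 1.2-fold higher number from compound 1 to compound 2 (0.09 log units; within the scatter), is within the scatter, so the number of compound 2 cannot be set apart from that of compound 1 in this assay; both stand close to one another.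

Compound 3 `Cc1ccc(-c2nc(=O)o[nH]2)c(-c2ccc([C@@H](C)N(CC3CC3)c3nc(C(=O)NS(=O)(=O)C4CC4)c(C4CC4)s3)cc2)c1` is not yet measured. It differs from compound 2 in one place: cyclopropyl in place of cyclobutyl on an aromatic carbon. Within the data shown here, the single measured step bears on this change only loosely, since it exchanged an open chain for a ring at the same aromatic carbon and stayed within the scatter. No step beyond the scatter is therefore expected here either, and the step expected in this assay is a 1.1-fold lower number from compound 2 to compound 3 (0.05 log units; within the scatter). For compound 3 the estimated half-life in this assay is 2.5 h, with a range from 1.4 h to 4.5 h.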

Compound 3, half-life: 3.1 h
For compound 3 the middle estimate is 1.2-fold (0.09 log units) below the measured one, within the range that was stated.
By their numbers in this assay, from the lowest: compounds 1, 2 and 3 (each within the scatter of the next).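

In this assay, the aromatic carbon next to the ring sulfur has now carried three different groups, and exchanging cyclobutyl for cyclopropyl gives a 1.1-fold higher number from compound 2 to compound 3 (0.04 log units; within the scatter). Within the data shown here, the wider comparison, cyclopropyl in place of the open isobutyl chain, gives a 1.3-fold higher number from compound 1 to compound 3 (0.13 log units; within the scatter), so the isobutyl, cyclobutyl and cyclopropyl groups cannot be told apart on this read-out, whereas the earlier step had set only one ring against the open chain. No measurement at hand speaks to why these three compounds stand so close.

Going by these compounds, all three groups consist of carbon only and hold no hydrogen-bond donors or acceptors, so it stays open whether an amine, a carboxylic acid or a methoxy group on this aromatic carbon would move the half-life beyond the scatter. On these data alone, it also stays open whether a bare hydrogen, a methyl group or a longer chain at this carbon would stand as close to these compounds, and whether changes elsewhere on the shared core would matter more.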